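The compounds below may be only part of what the source reports. "The series", "measured", "known", "first", "only" and "open" are said of these compounds alone.

Compound 1 `CCN1CCN(c2ccc(S(=O)(=O)Oc3cc(OC)cc(OC)c3)cc2)C1=O` and compound 2 `CCN1CCN(c2ccc(S(=O)(=O)Oc3cc(OC)c(OC)c(OC)c3)cc2)C1=O` differ in a single place. In a functional assay on MCF7 cells (Homo sapiens) for antiproliferative activity, read by sulforhodamine B assay, with a stated time of 48 h (on this read-out lower numbers stand for stronger inhibition and higher numbers for weaker inhibition), compound 1 gives 3500 nM, while compound 2 gives 700 nM. The change methoxy in place of hydrogen on an aromatic carbon made the step of a 5.0-fold lower number from compound 1 to compound 2 (0.70 log units; beyond the scatter). Compound 3 `CCCN1CCN(c2ccc(S(=O)(=O)Oc3cccc(OC)c3)cc2)C1=O` rests on a different core; the difference between the two cores is not broken down here. In this assay compound 3 gives 6300 nM, the highest of the three numbers, within the scatter of compound 1 and beyond the scatter against compound 2. Compound 4 `CCCN1CCN(c2ccc(S(=O)(=O)Oc3ccc(OC)c(OC)c3)cc2)C1=O` is not yet measured and differs from compound 3 by methoxy in place of hydrogen on an aromatic carbon. For the measured compounds named here, this is the same kind of change as the one between compound 1 and compound 2, not the same: there the entering methoxy stood ortho to two methoxy groups, here it stands ortho to a methoxy group; in both it is para to a large group. The step to compound 4 in this assay is estimated at a 4.2-fold lower number from compound 3 to compound 4 (0.62 log units; beyond the scatter), because the earlier instance gave a 5.0-fold lower number from compound 1 to compound 2 (0.70 log units; beyond the scatter), with the different surroundings leaving it less certain. Compound 4 is expected to give 1500 nM, in a range from 500 nM to 5000 nM.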

Compound 4, half-maximal inhibitory concentration: 6800 nM
Estimate against measurement, compound 4: 4.5-fold (0.66 log units) below, and the stated range ends below it.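

In this assay, methoxy in place of hydrogen on an aromatic carbon gives a 1.1-fold higher number from compound 3 to compound 4 (0.03 log units; within the scatter), so on the core of compound 3 this change leaves the two numbers within the scatter of each other. For the compounds shown here, the size of the step therefore does not carry from one core to the other, and the two instances disagree: the same change on two cores in this assay, a 5.0-fold lower number (0.70 log units; beyond the scatter) from compound 1 to compound 2 and a 1.1-fold higher number (0.03 log units; within the scatter) from compound 3 to compound 4, 5.4-fold (0.73 log units) apart, beyond the scatter of two such steps This does not show what sets them apart, since the instances differ in the ethyl or propyl chain, in the methoxy groups already present and in the surroundings of the entering methoxy, and each core offers only a single pair.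

Open, as far as these compounds go, is how methoxy behaves on the core of compound 1 with the surroundings it has in compound 4, and on the core of compound 3 with those it has in compound 2. Also open, from the compounds shown here alone, is whether a butyl chain in place of propyl, or an ethoxy group or a fluorine in place of the entering methoxy, would give a step of either size.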